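The compounds below may be only part of what the source reports. "The series", "measured", "known", "first", "only" and "open" are said of these compounds alone.

Measured compounds:
Compound 1 `COc1cccc(C(=O)c2ccc3c(ccn3S(=O)(=O)c3cccc(/C=C/C(=O)NO)c3)c2)c1` in an assay on isolated protein for inhibition of histone deacetylase 8 (Homo sapiens) (on this read-out lower numbers stand for stronger inhibition and higher numbers for weaker inhibition), gives 3530 nM.
Compound 2 `COc1cc(C(=O)c2ccc3c(ccn3S(=O)(=O)c3cccc(/C=C/C(=O)NO)c3)c2)cc(OC)c1OC` in this assay gives 1260 nM.

For the measured compounds named here, compound 2 stands lowest of the two numbers measured so far, with compound 1 as its only neighbour; the step of a 2.8-fold lower number from compound 1 to compound 2 (0.45 log units; beyond the scatter) is the single measured step. Compound 3 `Cc1ccc(C(=O)c2ccc3c(ccn3S(=O)(=O)c3cccc(/C=C/C(=O)NO)c3)c2)cc1` has not yet been measured. It differs from compound 2 by 4-methylphenyl in place of 3,4,5-trimethoxyphenyl on a carbonyl carbon. Going by the values given here, the only step that bears on this change is a 2.8-fold lower number from compound 1 to compound 2 (0.45 log units; beyond the scatter), which shows that the 3,4,5-trimethoxyphenyl group gives a lower number than 3-methoxyphenyl at the carbonyl carbon. The 4-methylphenyl group of compound 3 carries none of the methoxy groups, so its number is expected to move back toward that of compound 1, a step of a 2.4-fold higher number from compound 2 to compound 3 (0.38 log units; beyond the scatter) in this assay, though an outcome near compound 2 cannot be excluded. For compound 3 the estimate is 3000 nM, with a range from 1200 nM to 7500 nM.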

Compound 3, half-maximal inhibitory concentration: 4480 nM
Estimate against measurement, compound 3: 1.5-fold (0.17 log units) below; low and high end bracket the measured number.
By their numbers in this assay, from the lowest: compound 2; then compounds 1 and 3 (each within the scatter of the next).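

In this assay the group on the carbonyl carbon now has a second comparison: 4-methylphenyl in place of 3,4,5-trimethoxyphenyl gives a 3.6-fold higher number from compound 2 to compound 3 (0.55 log units; beyond the scatter) and so the lower number of compound 2 does not carry over to this group. For the compounds shown here, the other pair reads as a 1.3-fold higher number from compound 1 to compound 3 (0.10 log units; within the scatter) and so 3-methoxyphenyl and 4-methylphenyl cannot be told apart here, which leaves 3,4,5-trimethoxyphenyl as the only group of the three that stands apart. Nothing available explains why this group stands apart.

Open, on these data alone, is whether the lower number needs all three methoxy groups, which 3,5-dimethoxyphenyl or 4-methoxyphenyl on the same carbonyl carbon would test. Also open, as far as these compounds go, is how an aminophenyl or carboxyphenyl group would read at this place.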